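Swapping 3-hydroxybenzyl for 4-methoxybenzyl on a shared core

The source may report more compounds than this note shows. Statements on the series, on what has been measured and on what is new or still open speak of the compounds shown alone.

Measured so far in a functional assay on KYSE-450 cells (Homo sapiens) for inhibition, read by MTT assay, with a stated time of 48 h (on this read-out lower numbers stand for stronger inhibition and higher numbers for weaker inhibition), and nothing else:
- compound 1 `C/C=C/C(=O)N(Cc1ccc(OC)c(OC)c1)c1cc(OC)c(OC)c(OC)c1` gives 39100 nM in this test
- compound 2 `C/C=C/C(=O)N(Cc1cccc(O)c1)c1cc(OC)c(OC)c(OC)c1` gives 14700 nM in this test

Compound 2 holds the lower of the two numbers, and its gap to compound 1 lies beyond the usual scatter of repeated measurements. The next compound to be tested is compound 3 `C/C=C/C(=O)N(Cc1ccc(OC)cc1)c1cc(OC)c(OC)c(OC)c1`, which keeps the shared core and differs from compound 2 in one place: 4-methoxyphenyl in place of 3-hydroxyphenyl on a saturated chain carbon bound to an amide-type nitrogen.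

For the measured compounds named here, no two measured compounds differ in only one place, so no single measured step speaks directly to this change. Going by the values given here, the only guide is loose: compound 1, which also carries methoxy groups on that ring, sits at 39100 nM in this assay and thus higher than compound 2. A small move toward a higher number, not clearly beyond the scatter, is therefore expected, and the estimated step of a 1.6-fold higher number from compound 2 to compound 3 (0.21 log units; within the scatter) reflects that. For compound 3 the expected value is 24000 nM, with an estimated range from 9000 nM to 60000 nM in the same test.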

Compound 3, half-maximal inhibitory concentration: 420 nM
For compound 3 the middle estimate is 57-fold (1.76 log units) above the measured one, outside the stated range (below it).
By their numbers in this assay, from the lowest: compound 3; then compound 2; then compound 1.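

Compound 3 shows that this position, the saturated chain carbon bound to an amide-type nitrogen, is highly sensitive to what the attached aromatic ring carries: in this assay, putting 4-methoxyphenyl in place of 3-hydroxyphenyl gives a 35-fold lower number from compound 2 to compound 3 (1.54 log units; beyond the scatter). The second step shows that a methoxy group on this ring does not by itself give a low number, since hydrogen in place of one methoxy group on an aromatic carbon gives a 93-fold lower number from compound 1 to compound 3 (1.97 log units; beyond the scatter), so a single ring substituent separates the highest and lowest numbers of the three compounds. Nothing available here accounts for the size of either step.

The step between compound 2 and compound 3 replaces the hydroxy group with a methoxy group and also moves the substituent on the ring, so these compounds cannot show how much each of those two differences contributes. They also leave open how an ethoxy group, a longer chain on that oxygen, or an amine on the same ring would behave in this assay.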